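This account rests on a few compounds, and the source may have more. Where it says the series, first, only, none or still open, it means among the compounds named here.

Going by the values given here, in a functional assay on A2780 cells (Homo sapiens) for antiproliferative activity, read by MTT assay, with a stated time of 72 h (on this read-out higher numbers stand for weaker inhibition and lower numbers for stronger inhibition), three compounds built on a shared core have numbers so far. Compound 1 `COc1ccc(C2CC(c3ccccc3)=NN2C(=O)c2cc3ccccc3o2)cc1` gives 4.57 ug/mL, compound 2 `COc1ccc(C2CC(c3ccc(Cl)cc3)=NN2C(=O)c2cc3ccccc3o2)cc1OC` gives 6.29 ug/mL, and compound 3 `COc1ccc(C2CC(c3ccc(F)cc3)=NN2C(=O)c2cc3ccccc3o2)cc1` gives 23 ug/mL. Compound 3 therefore has the highest number of the three, which means the weakest inhibition, and its gaps to both others lie beyond the usual scatter.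

Compound 4 `COc1ccc(C2CC(c3ccc(F)cc3)=NN2C(=O)c2cc3ccccc3o2)cc1OC` changes compound 3 in one place: methoxy in place of hydrogen on an aromatic carbon, ortho to a methoxy group and meta to a large group, turning 4-methoxyphenyl into 3,4-dimethoxyphenyl (methoxy in place of hydrogen on an aromatic carbon).

Among the compounds with values here, no measured pair isolates this change. Within the data shown here, the only single-place step available is a 5.0-fold higher number from compound 1 to compound 3 (0.70 log units; beyond the scatter), a modest one that comes from fluoro in place of hydrogen, so it shows a different change and gives only a rough idea of size. The closest guide is compound 2, at 6.29 ug/mL, which already carries 3,4-dimethoxyphenyl but has chlorine where compound 4 has fluorine.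

A modest move towards a lower number in this assay is therefore expected, and the estimated step is a 2.1-fold lower number from compound 3 to compound 4 (0.32 log units; beyond the scatter). Compound 4 is estimated at 11 ug/mL, with an expected range from 4 ug/mL to 30 ug/mL.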

Compound 4, half-maximal inhibitory concentration: > 50 ug/mL
Compound 4 was reported as a limit (the forecaster's own chance of this, stated with the estimate: 3%); middle value at least 4.5-fold (0.65 log units) away from the limit.
By their numbers in this assay, from the lowest: compounds 1 and 2 (each within the scatter of the next); then compound 3. At a limit, above all of these: compound 4.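

Compound 4 is reported in this assay only as a limit, > 50 ug/mL. Even so, this gives the first direct reading of the aromatic carbon ortho to a methoxy group: with fluorine kept in place, methoxy entering there turns 4-methoxyphenyl into 3,4-dimethoxyphenyl and gives an at least 2.1-fold higher number from compound 3 to compound 4 (0.33 log units; beyond the scatter), which means weaker inhibition. The 3,4-dimethoxyphenyl group therefore does not secure a low number on its own, since with that group held fixed, fluoro in place of chloro gives an at least 7.9-fold higher number from compound 2 to compound 4 (0.90 log units; beyond the scatter), and fluoro in place of hydrogen had likewise given a 5.0-fold higher number from compound 1 to compound 3 (0.70 log units; beyond the scatter), so in both steps where fluoro enters, the number rises beyond the scatter.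

Going by these compounds, how far the number of compound 4 lies past its limit stays unknown, so the true size of both new steps cannot be read. Also open, on these data alone, are how 3,4-dimethoxyphenyl behaves with hydrogen where these compounds carry a halogen, and whether a hydroxy group, an amine or a longer ethoxy chain at this same carbon would give the same loss as methoxy.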